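A few compounds are considered here, and "the series" means these few. Any claim that something is new, unique, unknown or untested is made for them only; others in the source may bear on it.

Compound 1 `COc1ccc(-c2cc(-c3ccc(S(N)(=O)=O)cc3)cnc2N)cn1` — 1.8
Compound 2 `COc1ccc(-c2cc(-c3ccc(-n4cncn4)cc3)cnc2N)cn1` — 2.4

In a physicochemical assay for lipophilicity, at pH 7.4 (on this read-out higher numbers stand for higher lipophilicity and lower numbers for lower lipophilicity), compound 2 stands highest of the two numbers shown; compound 1 is its nearest neighbour, and the step from compound 1 to compound 2 was a number 0.60 log units higher from compound 1 to compound 2 (beyond the scatter). Compound 3 `COc1ccc(-c2cc(-c3ccc(-n4cccn4)cc3)cnc2N)cn1` has not been measured. It differs from compound 2 by 1H-pyrazol-1-yl in place of 1H-1,2,4-triazol-1-yl on an aromatic carbon. Going by the values given here, no measured step covers this exact change; the one measured step concerns another group, so it offers only a rough scale. A modest rise in this assay is expected, of about a number 0.50 log units higher from compound 2 to compound 3 (beyond the scatter). Compound 3 is therefore estimated at 2.9, with a range from 2.5 to 3.3.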

Compound 3, distribution coefficient: 3.1
Compound 3: the middle estimate sits 0.20 log units below what was measured; low and high end bracket the measured number.
By their numbers in this assay, from the lowest: compound 1; then compound 2; then compound 3.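

At this place, para to a large group, one five-membered aromatic ring does not stand in for another in this assay: with the heavy-atom count unchanged, 1H-pyrazol-1-yl in place of 1H-1,2,4-triazol-1-yl gives a number 0.70 log units higher from compound 2 to compound 3 (beyond the scatter) on its own. Measured against sulfamoyl, the same group gives a number 1.30 log units higher from compound 1 to compound 3 (beyond the scatter) in this read-out, the widest span among the three compounds. Nothing shown accounts for either step.

Open, on these data alone, is where an amine or a carboxylic acid at this place would fall in this assay relative to these groups. Also open, as far as these compounds go, is whether the same exchange of rings gives a similar step on any core other than the shared one.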